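The compounds below may be only part of what the source reports. "The series", "measured", "known", "first", "only" and "open" are said of these compounds alone.

Compound 2 (`Cc1ccc(NC(=O)C2CCN(c3ncccc3Cl)CC2)cc1Cl`) is the starting point for this step. In a physicochemical assay for solubility, at pH 4 (a higher number here means a more soluble compound, a lower number a less soluble compound), compound 2 reads < 4000 nM and this is a limit of the assay, not a number. For the measured compounds named here, the series so far shows the limit of < 4000 nM in this assay, at which 1 of the 3 values shown sits, while the other two readings are numbers.

Compound 1 (`Nc1cccnc1N1CCC(C(=O)Nc2ccc(-n3nccn3)c(Cl)c2)CC1`) gives 48000 nM in this assay and compound 3 (`Cc1cn(-c2cc(NC(=O)C3CCN(c4ncccc4Cl)CC3)cc(C(F)(F)F)c2)cn1`) gives 690000 nM in the same measurement. Going by the values given here, neither differs from compound 2 in one place only, so no measured step is available for comparison.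

Compound 4 (`CNC(=O)c1ncn(-c2ccc(NC(=O)C3CCN(c4ncccc4Cl)CC3)cc2Cl)n1`) carries 3-(methylcarbamoyl)-1H-1,2,4-triazol-1-yl in place of methyl on an aromatic carbon, ortho to a chloro group and para to a large group, as counted in 3-(methylcarbamoyl)-1H-1,2,4-triazol-1-yl in place of methyl on an aromatic carbon for the change.

Among the compounds with values here, the only guide is indirect. Compound 1, at 48000 nM and compound 3, at 690000 nM each carry a five-membered aromatic ring and each return a number, though both differ from compound 4 elsewhere too. A modest upward move in this assay is therefore expected, and it may not clear the scatter by much. The expected size is an at least 2.0-fold higher number from compound 2 to compound 4 (0.30 log units; that floor lies within the scatter) as a rough estimate, and a second reading at the limit remains possible. Compound 4 is estimated at 8000 nM with an expected range from 3000 nM to 40000 nM for the measurement.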

Compound 4, solubility: 8000 nM
The estimate for compound 4 equals the measured number at the digits printed; low and high end bracket the measured number.
By their numbers in this assay, from the lowest: compound 4; then compound 1; then compound 3. At a limit, below all of these: compound 2.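

Placing 3-(methylcarbamoyl)-1H-1,2,4-triazol-1-yl in place of methyl on an aromatic carbon, ortho to a chloro group and para to a large group, gives the first step that can be read at this position in this assay: an at least 2.0-fold higher number from compound 2 to compound 4 (0.30 log units; that floor lies within the scatter). Compound 2 sits at a limit of the assay and not at a number. Going by these compounds, the step is therefore a floor whose true size stays unknown, since one of its two ends is such a limit: the limit of < 4000 nM in this assay, at which 1 of the 4 values shown sits.

Compound 1 and compound 3 differ from compound 4 in more than one place, so those steps cannot be read, and the series offers no second change at this position to set against this one. On these data alone, whether the five-membered aromatic ring alone accounts for the step, or the methylcarbamoyl on it does, stays open, as does how a carboxylic acid or a primary amine in place of that methylcarbamoyl would read in this assay.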